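The source may report more compounds than this note shows. Statements on the series, on what has been measured and on what is new or still open speak of the compounds shown alone.

Compound 1, `CS(=O)(=O)Nc1cccc2c1CCC2c1ncc[nH]1`, is the starting point of this comparison. In a functional assay on CHO cells for agonist activity at Alpha-1D adrenergic receptor (Homo sapiens), read by FLIPR and calcium flux (a lower number here means that less compound is needed, a higher number that more compound is needed for the effect), compound 1 reaches only a limit of the assay, > 10000 nM, so no exact number is known for it. Two measured relatives share its core. Compound 2, `Cc1oncc1-c1cccc2c1CCC2c1ncc[nH]1`, also stops at a limit in this assay, > 10000 nM. Compound 3, `c1ccc(-c2cccc3c2CCC3c2ncc[nH]2)nc1`, likewise gives a limit, > 10000 nM. All three values sit at the limit of > 10000 nM in this assay, at which 3 of the 3 values shown sit, and so the steps between them cannot be read: a step that the two limits leave unreadable from compound 1 to compound 2, a step that the two limits leave unreadable from compound 1 to compound 3 and a step that the two limits leave unreadable from compound 2 to compound 3.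

The unmeasured compound 4, `COc1cccc2c1CCC2c1ncc[nH]1`, alters one group on the same core: methoxy in place of methanesulfonamido on an aromatic carbon. For the measured compounds named here, no measured step carries a readable size that bears on this change; every exchange at this aromatic carbon so far has left the compound at the limit. The expected step is therefore small or none, a number no higher from compound 1 to compound 4 (the limit leaves the size open), with no direction that can be trusted. Compound 4 is estimated to give about 10000 nM, between 2000 nM and 30000 nM, and a limit is again quite likely.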

Compound 4, half-maximal effective concentration: > 10000 nM
Compound 4: only a limit was reported (the forecaster's own chance of this, stated with the estimate: 70%); the middle value sits exactly at the limit.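

Compound 4 also stops at a limit of the assay, > 10000 nM. Its steps to compound 1, compound 2 and compound 3 therefore cannot be read: the limit of > 10000 nM in this assay, at which 4 of the 4 values shown sit.

The compounds shown leave open whether any group on this aromatic carbon gives an exact value in this assay.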